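Chloro to trifluoromethyl on the benzyl group of compound 2

The source may hold more compounds than are shown below. What is called first, only, known or untested is meant among the compounds shown, and "the series" means these compounds.

- compound 1 `COc1cc(OC)c(-c2coc3cc(OCC=C(C)C)ccc3c2=O)cc1OC`: 1580 nM
- compound 2 `COc1cc(OC)c(-c2coc3cc(OCc4cccc(Cl)c4)ccc3c2=O)cc1OC`: 980 nM

Both numbers come from a functional assay on A-375 cells (Homo sapiens) for antiproliferative activity, read by MTT assay, with a stated time of 24 h; a lower number here means a stronger inhibitor, a higher number a weaker inhibitor. Compound 1 and compound 2 are not separated, since compound 2, at 980 nM, lies within the scatter of compound 1.

Still unmeasured is compound 3 `COc1cc(OC)c(-c2coc3cc(OCc4cccc(C(F)(F)F)c4)ccc3c2=O)cc1OC`. It differs from compound 2 by one change: trifluoromethyl in place of chloro on an aromatic carbon. In words, 3-chlorobenzyl becomes 3-(trifluoromethyl)benzyl.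

Among the measured compounds shown here, only one measured step bears on this, and only indirectly: a 1.6-fold lower number from compound 1 to compound 2 (0.21 log units; within the scatter). That step replaced the whole group at the chain carbon and stayed within the scatter. For the measured compounds named here, no measured step changes a substituent on this aromatic ring, so the evidence is thin. No shift beyond the scatter is expected in this assay, and no direction is favoured.

The expected step is a 1.0-fold higher number from compound 2 to compound 3 (0.01 log units; within the scatter). The estimate for compound 3 is 1000 nM, with an expected range of 450 nM to 2200 nM.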

Compound 3, half-maximal inhibitory concentration: 1140 nM
For compound 3 the middle estimate is 1.1-fold (0.06 log units) below the measured one; low and high end bracket the measured number.
By their numbers in this assay, from the lowest: compounds 2, 3 and 1 (each within the scatter of the next).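

In this assay, the only substituent swap shown on this aromatic ring, trifluoromethyl in place of chloro, gives a 1.2-fold higher number from compound 2 to compound 3 (0.07 log units; within the scatter), so this ring carbon accepts four heavy atoms in place of one without separating the two compounds. The wider replacement at the chain carbon also stays unresolved with this second aryl group, at a 1.4-fold lower number from compound 1 to compound 3 (0.14 log units; within the scatter), so neither 3-chlorobenzyl nor 3-(trifluoromethyl)benzyl is separated from the chain of compound 1. Nothing available accounts for this flat reading.

As far as these compounds go, whether it holds for a different kind of group on this ring, such as an amine or a carboxylic acid, remains open. Also open, from the compounds shown here alone, are the unsubstituted benzyl group and a longer chain between the oxygen and the aromatic ring.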